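Working notes: benzyl on the ring nitrogen of compound 3

The compounds below may be only part of what the source reports. "The series", "measured", "known", "first", "only" and "open" are said of these compounds alone.

Measured compounds:
compound 1 `Clc1nss/c1=N\c1ccc(OCc2ccccc2)cc1` — in a functional assay on PANC-1 cells (Homo sapiens) for cytotoxicity, read by resazurin assay, with a stated time of 72 h (on this read-out higher numbers stand for weaker inhibition and lower numbers for stronger inhibition), compound 1 gives > 100000 nM, a limit of the assay and not a number.
compound 2 `Clc1nss/c1=N\c1ccc(Oc2ccccc2)cc1` — in this assay compound 2 gives 55000 nM.
compound 3 `Clc1nss/c1=N\c1cc(-c2ccccc2)n[nH]1` — in this assay compound 3 gives 23000 nM.

Compound 3 holds the lowest of the two numbers shown in this assay; the nearest is compound 2, and the gap between the two lies beyond the usual scatter. The remaining value, that of compound 1, is only a limit (the limit of > 100000 nM in this assay, at which 1 of the 3 values shown sits).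

Compound 4 `Clc1nss/c1=N\c1cc(-c2ccccc2)nn1Cc1ccccc1` differs from compound 3 in one place: benzyl in place of hydrogen on an aromatic nitrogen.

Within the data shown here, only one measured step is at hand, an at least 1.8-fold lower number from compound 1 to compound 2 (0.25 log units; that floor lies within the scatter). It concerns a benzyl group as well, but on an oxygen rather than on a ring nitrogen, in the opposite direction, and its floor lies within the scatter, so it offers no firm guidance for the size of the change from compound 3 to compound 4. No step beyond the scatter is therefore expected in this assay, with a slight lean towards a higher number; the expected step is a 1.3-fold higher number from compound 3 to compound 4 (0.12 log units; within the scatter).

Compound 4 is estimated at 30000 nM in this assay, with a range from 10000 nM to 100000 nM.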

Compound 4, half-maximal inhibitory concentration: 18000 nM
Estimate against measurement, compound 4: 1.7-fold (0.22 log units) above, within the range that was stated.
By their numbers in this assay, from the lowest: compounds 4 and 3 (each within the scatter of the next); then compound 2. At a limit, above all of these: compound 1.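

In this assay, benzyl in place of hydrogen on the aromatic nitrogen gives a 1.3-fold lower number from compound 3 to compound 4 (0.11 log units; within the scatter), so this position carries a group of 7 heavy atoms with no step beyond the scatter. Among these compounds, the hydrogen on that nitrogen is therefore not required to hold the value of compound 3 in this assay, something the earlier compounds could not show, as their only step placed benzyl or phenyl on an oxygen on an aromatic ring and none varied this nitrogen. Compound 1 alone remains at a limit of the assay, which is not a number: the limit of > 100000 nM in this assay, at which 1 of the 4 values shown sits.

Still open, from the compounds shown here alone, is whether this nitrogen takes other groups equally well, such as methyl, a longer alkyl chain, a chain ending in an amine, or a carboxylic acid, and whether a substituent such as fluorine or methoxy on the benzyl ring would give a step beyond the scatter. Also open, going by these compounds, is how the phenyl group on the same ring contributes, for instance whether pyridine or a plain methyl group could take its place with benzyl kept on the nitrogen.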